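The compounds below may be only part of what the source reports. "The series", "measured", "known", "first", "only" and "open" are said of these compounds alone.

Of the compounds shown here, three with a shared benzenesulfonyl hydrazide arm have been tested in an assay on isolated protein for inhibition of branched-chain-amino-acid aminotransferase, cytosolic (Homo sapiens); a higher number here means a weaker inhibitor, a lower number a stronger inhibitor. Compound 1 `O=C(NNS(=O)(=O)c1ccccc1)c1cc2ccccc2[nH]1` gives 36000 nM, and compound 2 `O=C(NNS(=O)(=O)c1ccccc1)c1cnc2ccccc2c1` gives 33300 nM. Compound 3 `O=C(NNS(=O)(=O)c1ccccc1)c1cc2cc(Br)ccc2o1` gives 2500 nM, the lowest of the three numbers; its gaps to compound 1 and to compound 2 both lie beyond the usual scatter, so compound 3 is the strongest inhibitor of the three in this assay.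

Compound 4 `O=C(NNS(=O)(=O)c1ccccc1)c1cc2cc(Cl)ccc2o1` differs from compound 3 in one place: chloro in place of bromo on an aromatic carbon. Within the data shown here, no measured pair here shows what such a swap does, so the expectation rests on the single change itself. Exchanging one halogen for another at the same aromatic carbon is a small alteration, and the step from compound 3 to compound 4 is expected to be small, either within the scatter or a modest move toward a higher number.

Compound 4 is therefore estimated at 3500 nM in this assay, with a likely range from 1500 nM to 8000 nM, an expected step of a 1.4-fold higher number from compound 3 to compound 4 (0.15 log units; within the scatter).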

Compound 4, half-maximal inhibitory concentration: 4200 nM
Estimate against measurement, compound 4: 1.2-fold (0.08 log units) below; the range from low to high includes it.
By their numbers in this assay, from the lowest: compounds 3 and 4 (each within the scatter of the next); then compounds 2 and 1 (each within the scatter of the next).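

Among these compounds, compound 3 and compound 4 form the first pair here that differs in only one place, so they give the first direct reading of this aromatic carbon. In this assay, chloro in place of bromo gives a 1.7-fold higher number from compound 3 to compound 4 (0.23 log units; within the scatter), which means that this measurement cannot tell the two halogens apart at this position. No available measurement explains this result.

Both compounds carry a halogen on this carbon, so the pair leaves open whether a halogen is needed there at all, a question that a compound with plain hydrogen at the same place could answer. It also leaves open how far the position accepts groups of a different kind, such as an amine, a methoxy group or a carboxylic acid, since the step between two halogens says little about them.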